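From a Nitrile to Two Methyls on the Sulfonyl Group

The compounds below may be only part of what the source reports. "The series", "measured", "known", "first", "only" and "open" are said of these compounds alone.

Of the compounds shown here, three sharing one core have been measured in an ADME assay on microsomes from liver (Homo sapiens) for metabolic stability, tested at 2.5 uM; on this read-out lower numbers stand for slow clearance and higher numbers for fast clearance. Compound 1 `COc1ccc(-c2c(S(=O)(=O)c3cccc(C#N)c3)cnc3cc(F)ccc23)cc1` gives 0.92 mL/min, compound 2 `COc1ccc(S(=O)(=O)c2cnc3c(F)cccc3c2-c2cccc(F)c2)cc1` gives 3.03 mL/min, and compound 3 `N#Cc1cccc(S(=O)(=O)c2cnc3cc(F)ccc3c2-c2cccc(Cl)c2)c1` gives 0.99 mL/min. Compound 3 thus stands second highest of the three, within the scatter of compound 1 and clearly apart from compound 2. For the measured compounds named here, the only measured step, a 1.1-fold higher number from compound 1 to compound 3 (0.03 log units; within the scatter), changed the aryl group on the core rather than the group on the sulfonyl sulfur. Compound 4 `Cc1ccc(S(=O)(=O)c2cnc3cc(F)ccc3c2-c2cccc(Cl)c2)cc1C` differs from compound 3 by 3,4-dimethylphenyl in place of 3-cyanophenyl on a sulfonyl sulfur. Going by the values given here, no measured step bears directly on this change; compound 2, which carries another group on the sulfonyl sulfur, shows a higher number than compound 3, but it also differs elsewhere. In this assay a step of a 2.0-fold higher number from compound 3 to compound 4 (0.31 log units; beyond the scatter) is expected. Compound 4 is estimated at 2 mL/min, with a range from 0.9 mL/min to 4.5 mL/min.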

Compound 4, intrinsic clearance in a liver preparation (reported as CLH), per the amount of preparation that the assay uses: 4.01 mL/min
Compound 4: the middle estimate sits 2.0-fold (0.30 log units) below what was measured, and the stated range covers the measured number.
By their numbers in this assay, from the lowest: compounds 1 and 3 (each within the scatter of the next); then compounds 2 and 4 (each within the scatter of the next).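

Among the changes shown, swapping the group on the sulfonyl sulfur is the one that moves the number beyond the scatter: in this assay, 3,4-dimethylphenyl in place of 3-cyanophenyl gives a 4.1-fold higher number from compound 3 to compound 4 (0.61 log units; beyond the scatter). The swap on the core's aryl group, by contrast, gave a 1.1-fold higher number from compound 1 to compound 3 (0.03 log units; within the scatter). Nothing available here explains why the number rises.

On these data alone, whether the rise follows the loss of the nitrile or the arrival of the two methyls stays open. A plain phenyl or a 3-methylphenyl on the sulfonyl sulfur could separate the two.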